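A few compounds are considered here, and "the series" means these few. Any claim that something is new, unique, unknown or untested is made for them only; others in the source may bear on it.

Of the compounds shown here, three have been tested in a functional assay on HeLa cells (Homo sapiens) for cytotoxicity, read by WST assay, with a stated time of 48 h; a higher number here means a weaker inhibitor, a lower number a stronger inhibitor. Compound 1 `COc1cccc([C@H](O)[C@H]2CO[C@H](c3ccc(OC)c(OC)c3)[C@@H](C/C=C/c3ccc(OC)c(OC)c3)C2)c1` gives 21200 nM, compound 2 `COc1ccc([C@H]2OC[C@H]([C@@H](O)c3ccc(OC)c(OC)c3)C[C@@H]2C/C=C/c2ccc(OC)c(OC)c2)cc1` gives 46700 nM, and compound 3 `O[C@@H](c1ccccc1)[C@H]1CO[C@H](c2ccccc2)[C@@H](C/C=C/C2CCCCC2)C1` gives 6440 nM. Compound 3 thus has the lowest number of the three, a difference from compound 1 and compound 2 that lies beyond the usual scatter, which makes it the strongest inhibitor measured so far.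

Compound 4 `O[C@@H](c1ccccc1)[C@H]1CO[C@H](c2ccccc2)[C@@H](C/C=C/c2ccccc2)C1` differs from compound 3 in a single place: phenyl in place of cyclohexyl on a double-bonded chain carbon bound to a double-bonded chain carbon. Compound 1 and compound 2 carry aromatic rings at the matching position yet differ from compound 3 elsewhere too, so they do not tell what this change alone does.

For compound 4 the step is expected to be small, a 1.2-fold higher number from compound 3 to compound 4 (0.09 log units; within the scatter), with no clear direction beyond the scatter. Compound 4 is therefore estimated at 8000 nM, within a range of 3000 nM to 22000 nM.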

Compound 4, half-maximal inhibitory concentration: 6060 nM
The estimate for compound 4 lay 1.3-fold (0.12 log units) above the measured number; low and high end bracket the measured number.
By their numbers in this assay, from the lowest: compounds 4 and 3 (each within the scatter of the next); then compound 1; then compound 2.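

In this assay, phenyl in place of cyclohexyl gives a 1.1-fold lower number from compound 3 to compound 4 (0.03 log units; within the scatter). For the compounds shown here, at this position, then, an aromatic and a non-aromatic six-membered carbon ring cannot be told apart by this read-out, something the earlier compounds, which differ in more than one place, could not show. No measurement at hand explains this match.

From the compounds shown here alone, what an amine, a carboxylic acid or a longer chain would do on this double-bonded chain carbon stays open. So does the effect of methoxy groups on this phenyl taken alone.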